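Extending the ring at the exocyclic carbon of the shared core

This account rests on a few compounds, and the source may have more. Where it says the series, first, only, none or still open, it means among the compounds named here.

Compound 1 `CCOC(=O)C1=C(Nc2ccccc2)S/C(=C\c2ccc(OC)cc2)C1=O` carries a 4-methoxyphenyl on the double-bonded chain carbon bound to a double-bonded ring carbon. In a functional assay on MCF7 cells (Homo sapiens) for inhibition, read by MTT assay, with a stated time of 72 h, tested at 10 uM (a higher number here means more inhibition at the concentration tested (going by the name of the read-out), a lower number less inhibition), compound 1 gives 14.7%. Compound 2 `CCOC(=O)C1=C(Nc2ccccc2)S/C(=C\c2cc[nH]c2)C1=O` differs only in having a 1H-pyrrol-3-yl at that place. In this assay compound 2 reaches only the assay's limit, < 10%, not a number (the limit of < 10% in this assay, at which 1 of the 2 values shown sits). The step of a number at least 4.7 percentage points lower from compound 1 to compound 2 (that floor lies within the scatter) is therefore a drop whose floor lies within the scatter, and compound 2 stands at the limit among the two values shown.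

Compound 3 `CCOC(=O)C1=C(Nc2ccccc2)S/C(=C\c2cc3cccnc3[nH]2)C1=O` is not yet measured. It changes compound 2 by a group of 9 heavy atoms (7 carbon, 2 nitrogen; one five-membered aromatic ring with 1 hetero atom, one six-membered aromatic ring with 1 hetero atom) in place of a group of 5 heavy atoms (4 carbon, 1 nitrogen; one five-membered aromatic ring with 1 hetero atom), on a double-bonded chain carbon bound to a double-bonded ring carbon.

Among the measured compounds shown here, only the step from compound 1 to compound 2 bears on this change, and it brought inhibition from a modest number to the limit. Nothing in the two values shown points toward a rise for a larger aromatic group at this place. Compound 3 is therefore expected to stay near the limit, with an estimated step of a number at least 2 percentage points higher from compound 2 to compound 3 (that floor lies within the scatter) that is within the scatter. The estimate for compound 3 in this assay is 12%, between 0% and 28%.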

Compound 3, a percentage reported as inhibition, at one concentration (the size of the read-out at that concentration, not a potency): 18.2%
Beside the measured number, compound 3's estimate is 6.2 percentage points below it; the measured number falls inside the stated range.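

The change at this place, on a double-bonded chain carbon bound to a double-bonded ring carbon, turns a limit into a number, and the group of 9 heavy atoms gives a number at least 8.2 percentage points higher from compound 2 to compound 3 (that floor lies within the scatter), so a rise over the 1H-pyrrol-3-yl compound is not established. Against the 4-methoxyphenyl group the result is a number 3.5 percentage points higher from compound 1 to compound 3 (within the scatter), which means that a group with one six-membered aromatic ring of carbon only and a group with a five-membered and a six-membered aromatic ring cannot be told apart in this assay. Compound 2 remains the only compound at a limit, which is not a number: the limit of < 10% in this assay, at which 1 of the 3 values shown sits.

The compounds shown leave open whether any group at this place can give inhibition clearly beyond the scatter in this assay, as all the readings come from a single tested concentration. They also leave open what the hetero atom of the six-membered ring contributes, and whether an amine or a carboxylic acid on the aromatic group, or a plain alkyl chain in its place, would change the reading.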